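The source may report more compounds than this note shows. Statements on the series, on what has been measured and on what is new or still open speak of the compounds shown alone.

Measured in a functional assay on HeLa cells (Homo sapiens) for cytotoxicity, read by MTT assay, with a stated time of 72 h; a lower number here means a stronger inhibitor, a higher number a weaker inhibitor:

Compound 1, `N/C(=N\NC(=S)N1CCSCC1)c1ccccn1`, gives 7800 nM.
Compound 2, `N/C(=N\NC(=S)N1CCOCC1)c1ccc(F)cn1`, gives 1700 nM.

Compound 2 stands at the lower of the two values in this assay: its number lies well under that of compound 1, and the gap between them is beyond the usual scatter of repeated measurements. Among the compounds with values here, compound 1 and compound 2 differ in two places at once, so no single step between them can be read off.

Compound 3, `N/C(=N\NC(=S)N1CCSCC1)c1ccc(F)cn1`, has not yet been measured in this assay. It differs from compound 2 in one place: thiomorpholin-4-yl in place of morpholin-4-yl on a thiocarbonyl carbon. Within the data shown here, the same exchange appears nowhere among the measured pairs, so there is no measured step on which to rest an expectation for its size or direction. What compound 1 shows is that the thiomorpholin-4-yl group sits on a compound with a weaker number, but that compound also lacks the fluorine of compound 2, so its value cannot be assigned to the ring alone.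

Among the measured compounds shown here, with no step to lean on, the step from compound 2 to compound 3 is expected to stay within the scatter, a 1.5-fold higher number from compound 2 to compound 3 (0.17 log units; within the scatter), with a slight lean toward the weaker side. Compound 3 is therefore estimated at 2500 nM, with a range from 1000 nM to 7000 nM.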

Compound 3, half-maximal inhibitory concentration: 1700 nM
Beside the measured number, compound 3's estimate is 1.5-fold (0.17 log units) above it, and the stated range covers the measured number.
By their numbers in this assay, from the lowest: compounds 2 and 3 (each within the scatter of the next); then compound 1.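

In this assay the exchange of morpholin-4-yl for thiomorpholin-4-yl on a thiocarbonyl carbon gives no change at the digits printed from compound 2 to compound 3 (within the scatter) and so shows that, with the fluoro group present, the assay does not separate these two rings at this position. The fluoro group can now be read on its own, with thiomorpholin-4-yl held constant: fluoro in place of hydrogen on an aromatic carbon gives a 4.6-fold lower number from compound 1 to compound 3 (0.66 log units; beyond the scatter) and thus accounts for a clear step that the earlier pair, differing in two places, could not assign to either change. Nothing at hand explains either step.

The compounds shown leave open whether the two rings would also stay level without the fluoro group, and whether a chloro or methyl group in its place would carry a similar step. Also open, from the compounds shown here alone, is how a piperidin-1-yl or dimethylamino group on the thiocarbonyl carbon would compare with morpholin-4-yl and thiomorpholin-4-yl.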